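The source may hold more compounds than are shown below. What is called first, only, known or untested is meant among the compounds shown, and "the series" means these compounds.

Working notes on the substituent on the nitrogen, read in an in vitro ADME assay on microsomes from liver (Homo sapiens) for metabolic stability; on this read-out lower numbers stand for slow clearance and higher numbers for fast clearance. Compound 1 `Clc1ccc(-c2n[nH]cc2-c2ccnc(NC3CC3)n2)cc1`, with cyclopropyl at that place, gives 0.096 mL/min/kg. Compound 3 `Clc1ccc(-c2n[nH]cc2-c2ccnc(NC3CCCC3)n2)cc1`, with cyclopentyl there, gives 0.116 mL/min/kg. That step, a 1.2-fold higher number from compound 1 to compound 3 (0.08 log units; within the scatter), leaves the two compounds level, and compound 3 therefore stands with compound 1 on the numbers available. Compound 2 `C[C@H](CC(=O)O)Nc1nccc(-c2c[nH]nc2-c2ccc(Cl)cc2)n1`, carrying 1-(carboxymethyl)ethyl at the same place, gives < 0.006 mL/min/kg, which is a limit of the assay and not a number. The steps to and from it are large: an at least 16-fold lower number from compound 1 to compound 2 (1.20 log units; beyond the scatter) and an at least 19-fold higher number from compound 2 to compound 3 (1.28 log units; beyond the scatter). Both involve the 1-(carboxymethyl)ethyl group, so they say little about an exchange of one carbon-only ring for another.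

The next change leads to compound 4 `Clc1ccc(-c2n[nH]cc2-c2ccnc(NC3CCCCC3)n2)cc1`: cyclohexyl in place of cyclopentyl on a nitrogen on an aromatic ring. In words, this is cyclohexyl in place of cyclopentyl on a nitrogen on an aromatic ring. The closest measured precedent is the exchange of cyclopropyl for cyclopentyl, a 1.2-fold higher number from compound 1 to compound 3 (0.08 log units; within the scatter), so no step beyond the scatter is expected in this assay. The expected step is a 1.0-fold higher number from compound 3 to compound 4 (0.01 log units; within the scatter). For compound 4 the estimated clearance is 0.12 mL/min/kg, with an expected range from 0.06 mL/min/kg to 0.25 mL/min/kg.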

Compound 4, clearance: 0.156 mL/min/kg
The estimate for compound 4 lay 1.3-fold (0.11 log units) below the measured number; low and high end bracket the measured number.
By their numbers in this assay, from the lowest: compounds 1, 3 and 4 (each within the scatter of the next). At a limit, below all of these: compound 2.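

In this assay, the carbon-only rings on the nitrogen now run from cyclopropyl through cyclopentyl to cyclohexyl with no step beyond the scatter: a 1.3-fold higher number from compound 3 to compound 4 (0.13 log units; within the scatter), and a 1.6-fold higher number from compound 1 to compound 4 (0.21 log units; within the scatter). For the compounds shown here, the earlier compounds held only one such exchange, so the level reading could have been particular to that pair, whereas compounds 1, 3 and 4 now show it across three ring sizes, including the widest exchange available, cyclopropyl to cyclohexyl. The 1-(carboxymethyl)ethyl group stays apart from all three rings, with an at least 26-fold higher number from compound 2 to compound 4 (1.41 log units; beyond the scatter), and this step is a bound and not an exact size, as compound 2 stands at a limit of the assay and not at a number: the limit of < 0.006 mL/min/kg in this assay, at which 1 of the 4 values shown sits.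

On these data alone, it remains open whether the level run extends to an open chain such as isopropyl, or to a cyclohexyl ring carrying a hydroxyl or an amine. As far as these compounds go, it is also open which part of the 1-(carboxymethyl)ethyl group goes with the large steps, a question that the matching methyl ester or the same chain without its carboxylic acid could address.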